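The source may hold more compounds than are shown below. What is called first, only, known or untested is meant among the compounds shown, and "the series" means these compounds.

Compound 1 `O=C(CC1CCCC1)Nc1c(C(O)(C(F)(F)F)C(F)(F)F)ccc2ccccc12` gives 81 nM in an assay on LtK cells with ATP-sensitive inward rectifier potassium channel 11 (Homo sapiens) as the target (a higher number here means that more compound is needed for the effect, a lower number that less compound is needed), and stands lowest of the three numbers measured. Compound 2 `O=C(NCCCCCCCl)Nc1c(C(O)(C(F)(F)F)C(F)(F)F)ccc2ccccc12` gives 4840 nM; the step from compound 1 is a 60-fold higher number from compound 1 to compound 2 (1.78 log units; beyond the scatter). Compound 3 `O=C(Nc1c(C(O)(C(F)(F)F)C(F)(F)F)ccc2ccccc12)c1ccccc1Cl` gives 2040 nM, a step of a 25-fold higher number from compound 1 to compound 3 (1.40 log units; beyond the scatter), and from compound 2 the step is a 2.4-fold lower number from compound 2 to compound 3 (0.38 log units; beyond the scatter). Compound 4 `Cc1ccc(C(=O)Nc2c(C(O)(C(F)(F)F)C(F)(F)F)ccc3ccccc23)cc1` differs from compound 1 by 4-methylphenyl in place of cyclopentylmethyl on a carbonyl carbon. The step that bears on it is the one in which an aromatic six-membered ring replaces the cyclopentylmethyl group on the carbonyl carbon, a 25-fold higher number from compound 1 to compound 3 (1.40 log units; beyond the scatter), a large loss. Compound 4 is therefore expected to show a large rise, around a 15-fold higher number from compound 1 to compound 4 (1.17 log units; beyond the scatter), and an estimated value of 1200 nM within 300 nM to 5000 nM.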

Compound 4, half-maximal effective concentration: 76 nM
Compound 4: the middle estimate sits 16-fold (1.20 log units) above what was measured, and the stated range ends above it.
By their numbers in this assay, from the lowest: compounds 4 and 1 (each within the scatter of the next); then compound 3; then compound 2.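

In this assay, an aromatic ring on the carbonyl carbon is compatible with a low number: 4-methylphenyl in place of cyclopentylmethyl gives no change beyond the scatter (a 1.1-fold lower number from compound 1 to compound 4 (0.03 log units; within the scatter)). The loss at compound 3 therefore does not extend to every aromatic ring, as 4-methylphenyl in place of 2-chlorophenyl shows (a 27-fold lower number from compound 3 to compound 4 (1.43 log units; beyond the scatter)). The (6-chlorohexyl)amino group remains far from 4-methylphenyl (a 64-fold lower number from compound 2 to compound 4 (1.80 log units; beyond the scatter)). No available evidence accounts for these differences.

Open, as far as these compounds go, is whether 4-chlorophenyl or 2-methylphenyl tracks compound 4 or compound 3. Also open, from the compounds shown here alone, is how a phenyl ring carrying an amine or a carboxylic acid would read at this position.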